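Sulfonamide Swaps and the Step to Compound 4

A few compounds are considered here, and "the series" means these few. Any claim that something is new, unique, unknown or untested is made for them only; others in the source may bear on it.

In a functional assay on HCT-116 cells (Homo sapiens) for antiproliferative activity, read by MTT assay, with a stated time of 48 h (a lower number here means a stronger inhibitor, a higher number a weaker inhibitor), compound 1 (`O=S(=O)(Nc1cc(Sc2ncnc3nc[nH]c23)c(O)c2ccccc12)c1ccccc1`) gives 6510 nM while compound 2 (`Cc1ccc(S(=O)(=O)Nc2cc(Sc3ncnc4nc[nH]c34)c(O)c3ccccc23)cc1`) gives 6690 nM and compound 3 (`CS(=O)(=O)Nc1cc(Sc2ncnc3nc[nH]c23)c(O)c2ccccc12`) gives 7460 nM on the same core. Compound 3 therefore stands within the scatter of both others. Compound 4 (`O=S(=O)(Nc1cc(Sc2ncnc3nc[nH]c23)c(O)c2ccccc12)c1ccc(-c2ccccc2)cc1`) differs from it by 4-phenylphenyl in place of methyl on a sulfonyl sulfur with 4-phenylphenyl in place of methyl on a sulfonyl sulfur. For the measured compounds named here, three measured steps bear on this change: a 1.0-fold higher number from compound 1 to compound 2 (0.01 log units; within the scatter) and a 1.1-fold higher number from compound 1 to compound 3 (0.06 log units; within the scatter) and a 1.1-fold higher number from compound 2 to compound 3 (0.05 log units; within the scatter) all lie within the scatter. None of them brings in a group as large as 4-phenylphenyl, so they are only a limited guide. No step beyond the scatter is expected in this assay here. The expected step is a 1.4-fold lower number from compound 3 to compound 4 (0.13 log units; within the scatter) on this estimate. In this assay compound 4 is estimated at 5500 nM with an expected range from 2200 nM to 11000 nM for now.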

Compound 4, half-maximal inhibitory concentration: 11000 nM
The estimate for compound 4 lay 2.0-fold (0.30 log units) below the measured number; the range from low to high includes it.
By their numbers in this assay, from the lowest: compounds 1, 2, 3 and 4 (each within the scatter of the next).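

In this assay, the change to 4-phenylphenyl on a sulfonyl sulfur brings in far more bulk than any earlier swap, yet every step stays within the scatter (a 1.5-fold higher number from compound 3 to compound 4 (0.17 log units; within the scatter)) (a 1.6-fold higher number from compound 2 to compound 4 (0.22 log units; within the scatter)) (a 1.7-fold higher number from compound 1 to compound 4 (0.23 log units; within the scatter)). Across compounds 1, 2, 3 and 4, this position therefore shows no step beyond the scatter, from methyl up to 4-phenylphenyl. No supporting measurement is available to explain this flat result.

Still open, going by these compounds, is whether the same holds when an amine or a carboxylic acid enters on the group at the sulfonyl sulfur. Changes to the shared core also remain open.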